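From 4-methylphenoxy to 4-chlorophenoxy: working notes

The source may hold more compounds than are shown below. What is called first, only, known or untested is meant among the compounds shown, and "the series" means these compounds.

Measured in a functional assay on A549 cells (Homo sapiens) for antiproliferative activity, read by MTT assay, with a stated time of 48 h; on this read-out higher numbers stand for weaker inhibition and lower numbers for stronger inhibition
Compound 1 `Cc1ncc([N+](=O)[O-])n1CC(=O)N/N=C/c1cc2ccccc2nc1Oc1ccc(Cl)cc1` gives 9030 nM
Compound 2 `Cc1ccc2nc(Oc3ccccc3)c(/C=N/NC(=O)Cn3c([N+](=O)[O-])cnc3C)cc2c1` gives 7180 nM
Compound 3 `Cc1ccc(Oc2nc3ccc(C)cc3cc2/C=N/NC(=O)Cn2c([N+](=O)[O-])cnc2C)cc1` gives 1190 nM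

Compound 3 holds the lowest of the three numbers, with both others higher beyond the scatter. Compound 4 `Cc1ccc2nc(Oc3ccc(Cl)cc3)c(/C=N/NC(=O)Cn3c([N+](=O)[O-])cnc3C)cc2c1` has not yet been measured. It differs from compound 3 as chloro in place of methyl on an aromatic carbon, para to a large group. Going by the values given here, the one measured step at this place is a 6.0-fold lower number from compound 2 to compound 3 (0.78 log units; beyond the scatter), methyl in place of hydrogen. Among the compounds with values here, compound 1, the only measured compound with 4-chlorophenoxy, gives 9030 nM, but its core is not that of compound 4. Part of the gain is expected to be lost in this assay, so a modest rise is anticipated. The expected change is a 2.5-fold higher number from compound 3 to compound 4 (0.40 log units; beyond the scatter). For compound 4 the estimate is 3000 nM, within an expected range of 1100 nM to 8500 nM.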

Compound 4, half-maximal inhibitory concentration: 1230 nM
For compound 4 the middle estimate is 2.4-fold (0.39 log units) above the measured one, within the range that was stated.
By their numbers in this assay, from the lowest: compounds 3 and 4 (each within the scatter of the next); then compounds 2 and 1 (each within the scatter of the next).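

On the shared core, 4-chlorophenoxy and 4-methylphenoxy cannot be told apart, a 1.0-fold higher number from compound 3 to compound 4 (0.01 log units; within the scatter). Chloro in place of hydrogen on the phenoxy ring gives a 5.8-fold lower number from compound 2 to compound 4 (0.77 log units; beyond the scatter), so the gain at this place is not confined to methyl. Methyl in place of hydrogen, a 7.3-fold lower number from compound 1 to compound 4 (0.87 log units; beyond the scatter), closely matches the earlier methyl step: the same change on two cores in this assay, a 6.0-fold lower number (0.78 log units; beyond the scatter) from compound 2 to compound 3 and a 7.3-fold lower number (0.87 log units; beyond the scatter) from compound 1 to compound 4, 1.2-fold (0.09 log units) apart, within the scatter of two such steps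

Still open, as far as these compounds go, is whether a methoxy, an amine or a carboxylic acid in place of the chloro of compound 4 would keep the gain. Other cell lines remain unaddressed.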